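The compounds below may be only part of what the source reports. "The series", "measured", "known", "first", "only" and "open" are said of these compounds alone.

Going by the values given here, compound 2 `Cc1ccc(S(=O)(=O)NC(=O)Nc2ccccc2C(=O)/C=C/c2cc(O)ccc2[N+](=O)[O-])cc1` has the lower of the two numbers in an ADME assay on the whole organism for cytotoxicity, with Artemia salina as the target, with a stated time of 24 h; on this read-out higher numbers stand for an effect only at larger amounts of compound and lower numbers for an effect already at smaller amounts: compound 2 gives 18.3 ug/mL, while compound 1 `Cc1ccc(S(=O)(=O)NC(=O)Nc2ccccc2C(=O)/C=C/c2ccccc2[N+](=O)[O-])cc1` gives 40.1 ug/mL, and the only measured step is a 2.2-fold lower number from compound 1 to compound 2 (0.34 log units; beyond the scatter). Compound 3 `Cc1ccc(S(=O)(=O)NC(=O)Nc2ccccc2C(=O)/C=C/c2cccnc2)cc1` is compound 2 with pyridin-3-yl in place of 5-hydroxy-2-nitrophenyl on a double-bonded chain carbon bound to a double-bonded chain carbon. That measured step bears on it only in part: the hydroxy leaves again, but so does the nitro group, and the ring itself changes. The expected step is a 1.9-fold higher number from compound 2 to compound 3 (0.28 log units; within the scatter), a modest rise toward the number of compound 1. Compound 3 is therefore estimated at 35 ug/mL, within 15 ug/mL to 80 ug/mL.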

Compound 3, concentration for half-maximal effect: 14.1 ug/mL
Compound 3: the middle estimate sits 2.5-fold (0.39 log units) above what was measured; the measured number lies below the stated range.
By their numbers in this assay, from the lowest: compounds 3 and 2 (each within the scatter of the next); then compound 1.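

Replacing the whole 5-hydroxy-2-nitrophenyl ring with pyridin-3-yl on this chain carbon gives a 1.3-fold lower number from compound 2 to compound 3 (0.11 log units; within the scatter), so in this assay compound 2 and compound 3 cannot be told apart. Against the 2-nitrophenyl ring, the same pyridin-3-yl gives a 2.8-fold lower number from compound 1 to compound 3 (0.45 log units; beyond the scatter), so this smaller ring, with neither hydroxy nor nitro, does not return the number to that of compound 1. Nothing measured here explains these steps. As far as these compounds go, what an amine or a carboxylic acid on the pyridin-3-yl ring would do to the number stays open.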